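Amide replacement on compound 1: lipophilicity notes

The source may report more compounds than this note shows. Statements on the series, on what has been measured and on what is new or still open speak of the compounds shown alone.

Measured so far:
compound 1 `C[C@H](Oc1ccc2ncc(/C=C/C(N)=O)c(C3CC3)c2c1)c1c(Cl)ccc(F)c1Cl` — > 5.5
compound 2 `Cc1cc(O[C@@H](C)c2c(Cl)ccc(F)c2Cl)ccc1/C=C/C(=O)O` — 3.2
compound 3 `C[C@H](Oc1ccnc(C2CC2)c1)c1c(Cl)ccc(F)c1Cl` — 4.3

Going by the values given here, in a physicochemical assay for lipophilicity, using the shake flask method (a lower number here means a more polar compound, a higher number a more lipophilic compound), compound 1 gives > 5.5, which is a limit of the assay and not a number; it is the one value of the three that sits at that limit (the limit of > 5.5 in this assay, at which 1 of the 3 values shown sits). In this assay compound 2 gives 3.2 and compound 3 gives 4.3. Compound 4 `C[C@H](Oc1ccc2ncc(/C=C/C(=O)N3CC[C@@H](N)[C@H](C(=O)O)C3)c(C3CC3)c2c1)c1c(Cl)ccc(F)c1Cl` is not yet measured. It differs from compound 1 in one place: a group of 10 heavy atoms (6 carbon, 2 nitrogen, 2 oxygen; one six-membered non-aromatic ring with 1 hetero atom) in place of one nitrogen atom, on a carbonyl carbon. Among the compounds with values here, no step between two measured compounds is available to guide the size of this change, so in this assay a step well beyond the scatter, downward, is expected. Compound 4 is estimated at 2.8 (range 1.8 to 3.8), which would be an expected step of a number at least 2.70 log units lower from compound 1 to compound 4 (beyond the scatter).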

Compound 4, distribution coefficient: 3.1
Compound 4: middle estimate off by 0.30 log units, on the low side; low and high end bracket the measured number.
By their numbers in this assay, from the lowest: compounds 4 and 2 (each within the scatter of the next); then compound 3. At a limit, above all of these: compound 1.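

In this assay, the six-membered non-aromatic ring group in place of the amino group on the carbonyl carbon gives a number at least 2.40 log units lower from compound 1 to compound 4 (beyond the scatter). Going by these compounds alone, this is the first step readable at this place, and the earlier compounds offered none. Compound 1 gives > 5.5, a limit of the assay and not a number: the limit of > 5.5 in this assay, at which 1 of the 4 values shown sits.

From the compounds shown here alone, how the same ring would read carrying only the amine, only the carboxylic acid or a hydroxyl group instead remains open. Going by these compounds, the share of the step belonging to each group therefore also remains open.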